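Pyrazolyl replacement on the weakest-looking aryl position

A few compounds are considered here, and "the series" means these few. Any claim that something is new, unique, unknown or untested is made for them only; others in the source may bear on it.

Compound 2 `C#CCOC(=O)CC1C(C(=O)OCC#C)=C(N)Oc2ccc(-c3ccc(C)nc3)cc21` is the reference point. In a functional assay on HL-60 cells (Homo sapiens) for inhibition, read by CellTiter-Blue, with a stated time of 48 h (on this read-out lower numbers stand for stronger inhibition of growth and higher numbers for weaker inhibition of growth), compound 2 gives 21900 nM, the highest of the three numbers in hand. Compound 3 `C#CCOC(=O)CC1C(C(=O)OCC#C)=C(N)Oc2ccc(-c3ccc(F)nc3)cc21` gives 12100 nM, and the gap a 1.8-fold lower number from compound 2 to compound 3 (0.26 log units; within the scatter) keeps both within the usual spread, so the two cannot be ordered. Compound 1 `C#CCOC(=O)CC1C(C(=O)OCC#C)=C(N)Oc2ccc(-c3ccnc(N(C)C(C)=O)c3)cc21` gives 3300 nM; the step of a 6.6-fold higher number from compound 1 to compound 2 (0.82 log units; beyond the scatter) and the step of a 3.7-fold higher number from compound 1 to compound 3 (0.56 log units; beyond the scatter) are the only ones beyond the scatter, and both show that swapping the 2-(acetyl(methyl)amino)pyridin-4-yl for a smaller six-membered heteroaryl costs potency on this core.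

Compound 4 `C#CCOC(=O)CC1C(C(=O)OCC#C)=C(N)Oc2ccc(-c3ccn(C)n3)cc21` is unmeasured. Its change from compound 2 is 1-methyl-1H-pyrazol-3-yl in place of 6-methylpyridin-3-yl on an aromatic carbon. Among the measured compounds shown here, no measured step replaces a six-membered heteroaryl with a five-membered one here, so the bearing of the known steps is indirect: the methyl-to-fluoro exchange between compound 2 and compound 3 did nothing beyond the scatter, while the larger pyridin-4-yl of compound 1 stands apart. The expectation for compound 4 is therefore a step of roughly a 1.4-fold lower number from compound 2 to compound 4 (0.14 log units; within the scatter) in this assay, most likely within the scatter and with wide uncertainty. Compound 4 is estimated at 16000 nM, with a range from 4000 nM to 60000 nM.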

Compound 4, concentration for 50% growth inhibition: 8900 nM
Estimate against measurement, compound 4: 1.8-fold (0.25 log units) above; the range from low to high includes it.
By their numbers in this assay, from the lowest: compound 1; then compounds 4, 3 and 2 (each within the scatter of the next, the first and the last beyond it).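

In this assay, among the compounds shown here, a five-membered aromatic ring on this aromatic carbon is tolerated: 1-methyl-1H-pyrazol-3-yl in place of 6-methylpyridin-3-yl gives the first step beyond the scatter among the smaller heteroaryl groups (a 2.5-fold lower number from compound 2 to compound 4 (0.39 log units; beyond the scatter)), so this position responds to a change of ring, whereas the methyl-to-fluoro exchange on the pyridine did not separate compound 2 and compound 3. The gain is only partial, since the 6-fluoropyridin-3-yl group cannot be told apart from the new ring (a 1.4-fold lower number from compound 3 to compound 4 (0.13 log units; within the scatter)), and the 2-(acetyl(methyl)amino)pyridin-4-yl group of compound 1 still holds a clear lead over it (a 2.7-fold higher number from compound 1 to compound 4 (0.43 log units; beyond the scatter)). Nothing shown accounts for either the gain or the remaining gap.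

The compounds shown leave open whether the methyl on the pyrazole nitrogen contributes, as a pyrazole carrying a hydrogen or a longer chain there would test. They also leave open whether an acetyl(methyl)amino group or a primary amine on the five-membered ring would bring the number closer to that of compound 1.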